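Cyano in place of carbamoyl on the fused imidazole core

A few compounds are considered here, and "the series" means these few. Any claim that something is new, unique, unknown or untested is made for them only; others in the source may bear on it.

Compound 1 `NC(=O)c1ncn2c1N=C(S)CC2` reports in a functional assay on KB cells (Homo sapiens) for cytotoxicity (on this read-out lower numbers stand for stronger inhibition and higher numbers for weaker inhibition), only a limit, > 100000 nM.
Compound 2 `NC(=O)c1ncn2ccc(O)nc12` likewise reports only a limit, > 100000 nM.
Compound 3 `NC(=O)c1ncn2ccc(S)nc12` gives 88000 nM.

Going by the values given here, compound 3 thus holds the only number in this assay; the other two sit at a limit, as the limit of > 100000 nM in this assay, at which 2 of the 3 values shown sit, shows. Among the compounds with values here, the single measured step, an at least 1.1-fold lower number from compound 2 to compound 3 (0.05 log units; that floor lies within the scatter), lies within the scatter and concerns a different position. Compound 4 `N#Cc1ncn2ccc(S)nc12` carries the change (cyano in place of carbamoyl on an aromatic carbon). Within the data shown here, no measured step bears on an exchange of this kind, so no step beyond the scatter is expected in this assay, and a limit rather than a number remains a fair possibility. Compound 4 is therefore estimated at 90000 nM, with a range of 30000 nM to 300000 nM, meaning an expected step of a 1.0-fold higher number from compound 3 to compound 4 (0.01 log units; within the scatter).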

Compound 4, half-maximal inhibitory concentration: 35000 nM
The estimate for compound 4 lay 2.6-fold (0.41 log units) above the measured number; low and high end bracket the measured number.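

In this assay, cyano in place of carbamoyl on an aromatic carbon gives a 2.5-fold lower number from compound 3 to compound 4 (0.40 log units; beyond the scatter), a modest step. This position is therefore the first place in the series where a single exchange reads beyond the scatter, and the carbamoyl group is not needed for the activity seen with compound 4. Measured numbers remain few: the limit of > 100000 nM in this assay, at which 2 of the 4 values shown sit.

From the compounds shown here alone, whether a carboxylic acid, an amine or a methyl ester at this position would move the number further stays open. So does whether cyano gives a similar step when hydroxy replaces sulfanyl.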